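Substituent change at the saturated ring carbon

This account rests on a few compounds, and the source may have more. Where it says the series, first, only, none or still open, it means among the compounds named here.

Compound 1 `Cc1c(C(C)C)c(=O)on1C(=O)N1CCC(Cc2ccccc2)CC1` gives 102 nM in an assay (strain Wistar) for inhibition of Hormone-sensitive lipase (Rattus norvegicus), read by spectrophotometry; a lower number here means a stronger inhibitor, a higher number a weaker inhibitor. Compound 2 `Cc1c(C(C)C)c(=O)on1C(=O)N1CCC(c2cccc(F)c2)CC1` gives 12 nM in this assay.

Compound 2 stands lowest of the two numbers; compound 1 is the nearest, with an 8.5-fold lower number from compound 1 to compound 2 (0.93 log units; beyond the scatter). Compound 3 `Cc1c(C(C)C)c(=O)on1C(=O)N1CCC(C(=O)N(C)C)CC1` differs from compound 2 by dimethylcarbamoyl in place of 3-fluorophenyl on a saturated ring carbon. Among the compounds with values here, the only measured step at this ring carbon is an 8.5-fold lower number from compound 1 to compound 2 (0.93 log units; beyond the scatter), which bears only loosely on an aromatic ring giving way to dimethylcarbamoyl. For compound 3 a higher number is expected, a 13-fold higher number from compound 2 to compound 3 (1.10 log units; beyond the scatter), with wide uncertainty. Compound 3 is estimated at 150 nM, between 30 nM and 800 nM.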

Compound 3, half-maximal inhibitory concentration: > 1000 nM
Compound 3: no number, only a limit; the forecaster's own chance of this, stated with the estimate: 10%; at least 6.6-fold (0.82 log units) between middle value and limit.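

Compound 3 gives only a limit in this assay, > 1000 nM, and not a number. Dimethylcarbamoyl falls behind both aromatic groups at this saturated ring carbon, with an at least 83-fold higher number from compound 2 to compound 3 (1.92 log units; beyond the scatter) and an at least 9.8-fold higher number from compound 1 to compound 3 (0.99 log units; beyond the scatter), so this position does not accept every substituent equally. Both step sizes are lower bounds, not measured gaps: the limit of > 1000 nM in this assay, at which 1 of the 3 values shown sits.

The compounds shown do not separate the loss of the aromatic ring from the entry of the carbonyl. As far as these compounds go, whether a cyclohexyl group, an unsubstituted phenyl or an amine at this ring carbon would stay close to compound 2 remains open.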